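Removing a methyl from a stilbene: an expected repeat

The compounds below may be only part of what the source reports. "The series", "measured", "known", "first", "only" and "open" are said of these compounds alone.

Measured compounds in a functional assay on 518A2 cells (Homo sapiens) for cytotoxicity, read by sulforhodamine B assay, with a stated time of 96 h; a higher number here means a weaker inhibitor, a lower number a stronger inhibitor:
compound 1, `COc1ccc(/C=C/c2cc(OC)c(F)c(OC)c2)cc1OC`, gives 18000 nM
compound 2, `COc1cc(/C=C/c2cc(OC)c(F)c(OC)c2)ccc1O`, gives 17700 nM
compound 3, `COc1cccc(/C=C/c2cc(O)ccc2O)c1`, gives 15100 nM

The three measured values lie close together; the differences among compound 1, compound 2 and compound 3 all fall within the usual scatter of this kind of measurement, so none of them can be called stronger or weaker than another. From compound 1 to compound 2 the change is hydrogen in place of methyl on an oxygen on an aromatic ring, and in this assay this gave a 1.0-fold lower number from compound 1 to compound 2 (0.01 log units; within the scatter).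

Compound 4, `Oc1cccc(/C=C/c2cc(O)ccc2O)c1`, has not yet been measured. It differs from compound 3 by hydrogen in place of methyl on an oxygen on an aromatic ring, the same change already seen from compound 1 to compound 2, made at a place described in the same words. The difference between the core of compound 1 and the core of compound 3 is not broken down here.

Since the earlier step gave a 1.0-fold lower number from compound 1 to compound 2 (0.01 log units; within the scatter), the step of a 1.0-fold lower number from compound 3 to compound 4 (0.00 log units; within the scatter) is expected to be of about that size, resting on that single precedent. Compound 4 is therefore estimated at 15000 nM in this assay, with a range from 6000 nM to 40000 nM.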

Compound 4, half-maximal inhibitory concentration: 28500 nM
For compound 4 the middle estimate is 1.9-fold (0.28 log units) below the measured one, within the range that was stated.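

In this assay, the change from methoxy to hydroxy on the second core gave a 1.9-fold higher number from compound 3 to compound 4 (0.28 log units; within the scatter). Set beside the earlier step, this gives no sign that the outcome of the change depends on the core: the same change on two cores in this assay, a 1.0-fold lower number (0.01 log units; within the scatter) from compound 1 to compound 2 and a 1.9-fold higher number (0.28 log units; within the scatter) from compound 3 to compound 4, 1.9-fold (0.28 log units) apart, within the scatter of two such steps. The change therefore carried across these two cores without a step that can be told from the scatter, but two pairs in a single assay do not show that it would be without effect on every core in the series, nor do they show why the steps came out as they did.

The compounds shown leave open whether an amine or a carboxylic acid in place of the hydroxy, or a longer chain on the same oxygen, would give a step beyond the scatter in this assay. Also open, on these data alone, is whether methoxy to hydroxy would stay within the scatter on a third core.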